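Swapping the aryl group on the chain of compound 3

A few compounds are considered here, and "the series" means these few. Any claim that something is new, unique, unknown or untested is made for them only; others in the source may bear on it.

Of the compounds shown here, three sharing one core have been measured in a functional assay on HL-60 cells (Homo sapiens) for cytotoxicity, read by WST assay, with a stated time of 48 h; a lower number here means a stronger inhibitor, a higher number a weaker inhibitor. Compound 1 `COc1ccccc1/C=C/C[C@H]1C[C@@H]([C@@H](O)c2ccccc2)CO[C@@H]1c1ccccc1` gives 10100 nM. Compound 2 `CCCCCC/C=C/C[C@H]1C[C@@H]([C@@H](O)c2ccccc2)CO[C@@H]1c1ccccc1` gives 4990 nM, and compound 3 `Oc1ccc(/C=C/C[C@H]2C[C@@H]([C@@H](O)c3ccccc3)CO[C@@H]2c2ccccc2)cc1` gives 7380 nM. Among these three numbers compound 3 stands second highest; its nearest neighbour is compound 1, and its value and that of compound 2 lie within the usual scatter of each other, so no order among them can be read. Within the data shown here, the only step beyond the scatter is a 2.0-fold lower number from compound 1 to compound 2 (0.31 log units; beyond the scatter). The steps of a 1.4-fold lower number from compound 1 to compound 3 (0.14 log units; within the scatter) and a 1.5-fold higher number from compound 2 to compound 3 (0.17 log units; within the scatter) show that exchanging the group on the double-bonded chain carbon bound to a double-bonded chain carbon changed little.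

Compound 4 `O=[N+]([O-])c1cccc(/C=C/C[C@H]2C[C@@H]([C@@H](O)c3ccccc3)CO[C@@H]2c2ccccc2)c1` has not yet been measured. It differs from compound 3 in one place: 3-nitrophenyl in place of 4-hydroxyphenyl on a double-bonded chain carbon bound to a double-bonded chain carbon. Among the measured compounds shown here, the steps that bear on this change are the three that also exchange this group, and each of them was modest or within the scatter. A step of similar size, or none beyond the scatter, is therefore expected in this assay, with no clear direction. The expected step is a 1.1-fold lower number from compound 3 to compound 4 (0.02 log units; within the scatter). For compound 4 the estimate is 7000 nM, with a range from 3000 nM to 16000 nM.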

Compound 4, half-maximal inhibitory concentration: 6350 nM
Estimate against measurement, compound 4: 1.1-fold (0.04 log units) above; the range from low to high includes it.
By their numbers in this assay, from the lowest: compounds 2, 4, 3 and 1 (each within the scatter of the next, the first and the last beyond it).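

In this assay, compound 4 brings a nitrogen-containing 3-nitrophenyl with no hydrogen-bond donor in place of the hydroxyl-bearing 4-hydroxyphenyl, yet the result is only a 1.2-fold lower number from compound 3 to compound 4 (0.07 log units; within the scatter). This substantial exchange of the aryl group therefore gives no readable change, and the same holds for the comparisons with the hexyl chain of compound 2, a 1.3-fold higher number from compound 2 to compound 4 (0.10 log units; within the scatter), and with the 2-methoxyphenyl of compound 1, a 1.6-fold lower number from compound 1 to compound 4 (0.20 log units; within the scatter). The new compound falls within the scatter of all three earlier ones, so among the four groups tried on the double-bonded chain carbon, only compound 1 and compound 2 stand apart, and no measurement at hand explains why the other exchanges change so little.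

The compounds shown leave open whether a different kind of group at this place, such as an amine, a carboxylic acid or a chain longer than hexyl, would produce a step beyond the scatter. They also leave open how the number would respond to a change on the shared core, which stays the same in all four compounds.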